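Keratinocyte Cytotoxicity Across Three Related Compounds

The compounds below may be only part of what the source reports. "The series", "measured", "known", "first", "only" and "open" are said of these compounds alone.

Compound 1 `Cc1cc(S(=O)(=O)/N=C(\N)n2nccc2-c2ccccc2)c(SCc2ccccc2Cl)cc1Cl` — 20000 nM
Compound 2 `Cc1cc(S(=O)(=O)/N=C(\N)n2nccc2-c2ccccc2)c(SCc2ccc(C(F)(F)F)cc2)cc1Cl` — 19000 nM

Of the compounds shown here, two have been measured in an ADME assay on HaCaT cells (Homo sapiens) for cytotoxicity, read by MTT assay, with a stated time of 72 h; on this read-out higher numbers stand for weaker inhibition and lower numbers for stronger inhibition. Compound 1 gives 20000 nM in this assay, and compound 2 gives 19000 nM. Among the compounds with values here, the one step between them, a 1.1-fold lower number from compound 1 to compound 2 (0.02 log units; within the scatter), shows that exchanging the group on the saturated chain carbon bound to a sulfur left the cytotoxicity unchanged within the scatter. Compound 2 holds the lowest of the two numbers, with compound 1 nearest to it, but the gap between them is within the scatter, so neither can be called more or less cytotoxic than the other.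

Compound 3 `Cc1cc(S(=O)(=O)/N=C(\N)n2nccc2-c2ccccc2)c(SCc2ccccc2C)cc1Cl` has not yet been measured. It differs from compound 2 as follows: 2-methylphenyl in place of 4-(trifluoromethyl)phenyl on a saturated chain carbon bound to a sulfur. Within the data shown here, the only measured step that bears on this change is the one from compound 1 to compound 2, which also varied the group at this same place and was within the scatter. On that basis, the step from compound 2 to compound 3 is expected to be a 1.1-fold higher number from compound 2 to compound 3 (0.02 log units; within the scatter), that is, nothing beyond the scatter. Compound 3 is therefore estimated at 20000 nM in this assay, with a range from 10000 nM to 40000 nM.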

Compound 3, half-maximal inhibitory concentration: 18000 nM
Compound 3: middle estimate off by 1.1-fold (0.05 log units), on the high side, and the stated range covers the measured number.
By their numbers in this assay, from the lowest: compounds 3, 2 and 1 (each within the scatter of the next).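

In this assay, the three aryl groups at this place, 2-chlorophenyl, 4-(trifluoromethyl)phenyl and 2-methylphenyl, now give numbers that all lie within the scatter of one another: replacing 4-(trifluoromethyl)phenyl with 2-methylphenyl on a saturated chain carbon bound to a sulfur gives (a 1.1-fold lower number from compound 2 to compound 3 (0.02 log units; within the scatter)), so a substituent at a different ring position and of a different kind again leaves the number unmoved. Within the data shown here, compound 1 and compound 3 also form a pair the earlier compounds did not offer, a single change of methyl in place of chloro on an aromatic carbon, and this step (a 1.1-fold lower number from compound 1 to compound 3 (0.05 log units; within the scatter)) also stays within the scatter. No supporting data are available to explain these results.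

Going by these compounds, all three compounds keep a substituted phenyl ring at this place, so it remains open whether a carboxylic acid, an amine or a longer chain there would shift the number beyond the scatter. Because every step shown lies within the scatter, the compounds also leave open how far this cytotoxicity depends on the rest of the shared core, including the chloro group on its aromatic ring.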